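From dichlorophenyl to difluorophenyl: estimating compound 4

A few compounds are considered here, and "the series" means these few. Any claim that something is new, unique, unknown or untested is made for them only; others in the source may bear on it.

Measured so far in a functional assay on U-937 cells (Homo sapiens) for antiproliferative activity, read by CCK-8 assay, with a stated time of 48 h; a higher number here means a weaker inhibitor, a lower number a stronger inhibitor
Compound 1 `COc1ccc(Nc2nc(Nc3cc(C)[nH]n3)cc(N3CCN(C)CC3)n2)cc1OC` gives 150 nM
Compound 2 `Cc1cc(Nc2cc(N3CCN(C)CC3)nc(Nc3ccc(F)c(Cl)c3)n2)n[nH]1` gives 12.2 nM
Compound 3 `Cc1cc(Nc2cc(N3CCN(C)CC3)nc(Nc3ccc(Cl)c(Cl)c3)n2)n[nH]1` gives 17.9 nM

Compound 3 sits close to one measured neighbour, with a 1.5-fold higher number from compound 2 to compound 3 (0.17 log units; within the scatter), which is within the usual scatter. It sits far from the other, with an 8.4-fold lower number from compound 1 to compound 3 (0.92 log units; beyond the scatter), which is beyond the scatter.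

Compound 4 `Cc1cc(Nc2cc(N3CCN(C)CC3)nc(Nc3ccc(F)c(F)c3)n2)n[nH]1` has not been measured. It carries 3,4-difluorophenyl in place of 3,4-dichlorophenyl on a nitrogen on an aromatic ring.

The nearest guide is the exchange of fluoro and chloro on an aromatic carbon, the small step already seen between compound 2 and compound 3. The larger 12-fold lower number from compound 1 to compound 2 (1.09 log units; beyond the scatter) replaced 3,4-dimethoxyphenyl, a different change, so it says little here. Among the measured compounds shown here, no step beyond the scatter is therefore expected in this assay, though no measured compound shows this exact swap.

The estimated value for compound 4 is 18 nM, with an expected range from 7 nM to 45 nM. This estimate means an expected 1.0-fold higher number from compound 3 to compound 4 (0.00 log units; within the scatter).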

Compound 4, half-maximal inhibitory concentration: 29.9 nM
Beside the measured number, compound 4's estimate is 1.7-fold (0.22 log units) below it, and the stated range covers the measured number.
By their numbers in this assay, from the lowest: compounds 2, 3 and 4 (each within the scatter of the next, the first and the last beyond it); then compound 1.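

In this assay, putting 3,4-difluorophenyl in place of 3,4-dichlorophenyl on the nitrogen gives a 1.7-fold higher number from compound 3 to compound 4 (0.22 log units; within the scatter), so the two fully halogenated rings cannot be told apart at this position. Fluoro in place of chloro on the ring of the mixed compound is a different matter, with a 2.5-fold higher number from compound 2 to compound 4 (0.39 log units; beyond the scatter), so the halogen compounds do not all count as equal: the two ends of the series separate even though each neighbouring pair does not. All the same, 3,4-difluorophenyl keeps a clear lead over 3,4-dimethoxyphenyl, with a 5.0-fold lower number from compound 1 to compound 4 (0.70 log units; beyond the scatter).

No measurement here accounts for these differences.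

On these data alone, it also remains open whether a ring with a single fluoro, or one carrying trifluoromethyl or a nitrile, would stay with the halogen compounds or fall towards compound 1.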